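Three Inactive Ureas and an Untested Indanyl Analogue

The source may report more compounds than this note shows. Statements on the series, on what has been measured and on what is new or still open speak of the compounds shown alone.

Three compounds have been measured in a functional assay on KOPN-8 cells (Homo sapiens) for antiproliferative activity, with a stated time of 72 h; a higher number here means that more compound is needed for the effect, a lower number that less compound is needed:

compound 1, `COC(=O)c1cc(=O)c2cc(NC(=O)Nc3ccc(Cl)c(Cl)c3)ccc2[nH]1`, reported only as a limit, > 6350 nM
compound 2, `COC(=O)c1cc(=O)c2cc(NC(=O)Nc3ccc(F)c(Cl)c3)ccc2[nH]1`, reported only as a limit, > 6350 nM
compound 3, `COC(=O)c1cc(=O)c2cc(NC(=O)NCc3ccccc3)ccc2[nH]1`, reported only as a limit, > 19500 nM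

Compound 3 stands at the limit of > 19500 nM in this assay, at which 1 of the 3 values shown sits, in this assay, while compounds 1 and 2 stand at the limit of > 6350 nM in this assay, at which 2 of the 3 values shown sit. Each value is a limit rather than a number, so none of the steps among the three can be sized: a step that the two limits leave unreadable from compound 1 to compound 2, a step that the two limits leave unreadable from compound 1 to compound 3 and a step that the two limits leave unreadable from compound 2 to compound 3. Compound 4, `COC(=O)c1cc(=O)c2cc(NC(=O)Nc3ccc4c(c3)CCC4)ccc2[nH]1`, has not yet been measured. It differs from compound 3 by 2,3-dihydro-1H-inden-5-yl in place of benzyl on an amide-type nitrogen. The measured steps that bear on this change are those that exchanged an aromatic group on the urea nitrogen for benzyl, a step that the two limits leave unreadable from compound 1 to compound 3 and a step that the two limits leave unreadable from compound 2 to compound 3, and both remain unreadable. With no readable step to build on, the step from compound 3 to compound 4 is expected to be an at least 1.3-fold lower number from compound 3 to compound 4 (0.11 log units; that floor lies within the scatter), and most likely only another limit would be reported. Compound 4 is therefore estimated at 15000 nM in this assay, with a range from 3000 nM to 60000 nM.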

Compound 4, half-maximal effective concentration: > 24100 nM
Compound 4 was reported as a limit; the forecaster's own chance of this, stated with the estimate: 75%; at least 1.6-fold (0.20 log units) between middle value and limit.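

In this assay compound 4 gives > 24100 nM, which is a limit. Going by these compounds alone, compound 1, compound 2 and compound 3 are also limits, so no step to compound 4 can be read. The compounds shown leave open whether the group on the amide-type nitrogen affects the read-out at all.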